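A few compounds are considered here, and "the series" means these few. Any claim that something is new, unique, unknown or untested is made for them only; others in the source may bear on it.

Among the compounds with values here, in a functional assay on MDA-MB-231 cells (Homo sapiens) for antiproliferative activity, read by MTT assay, with a stated time of 48 h (on this read-out lower numbers stand for stronger inhibition and higher numbers for weaker inhibition), compound 2 `COc1ccccc1NC(=O)N1CCN(c2ncnc3sc(-c4ccc(N5CCN(C)CC5)cc4)cc23)CC1` gives 23200 nM, the higher of the two numbers measured so far. Within the data shown here, the only other measured compound, compound 1 `CN1CCN(c2ccc(-c3cc4c(N5CCN(C(=O)Nc6ccc(C#N)cc6)CC5)ncnc4s3)cc2)CC1`, gives 3930 nM. Compound 3 `CN1CCN(c2ccc(-c3cc4c(N5CCN(C(=O)Nc6ccc(F)cc6F)CC5)ncnc4s3)cc2)CC1` keeps the rest of compound 2 and changes one group: 2,4-difluorophenyl in place of 2-methoxyphenyl on an amide-type nitrogen. In short, 2,4-difluorophenyl stands in place of 2-methoxyphenyl on an amide-type nitrogen. Among the measured compounds shown here, only one measured step bears on this position: a 5.9-fold higher number from compound 1 to compound 2 (0.77 log units; beyond the scatter), with 2-methoxyphenyl in place of 4-cyanophenyl. This single step shows that a change of group here can move the number beyond the scatter, but it offers thin evidence for a difluorinated ring. A modest move toward lower numbers in this assay is therefore expected, smaller than that measured step. The estimated change is a 2.3-fold lower number from compound 2 to compound 3 (0.37 log units; beyond the scatter). The estimate for compound 3 is 10000 nM, with an expected range of 3000 nM to 30000 nM.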

Compound 3, half-maximal inhibitory concentration: 11400 nM
Estimate against measurement, compound 3: 1.1-fold (0.06 log units) below; low and high end bracket the measured number.
By their numbers in this assay, from the lowest: compound 1; then compound 3; then compound 2.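

In this assay, the group on this amide-type nitrogen now has three measured forms, and the new one falls between the other two: a 2.0-fold lower number from compound 2 to compound 3 (0.31 log units; beyond the scatter), while a 2.9-fold higher number from compound 1 to compound 3 (0.46 log units; beyond the scatter). The order therefore runs from 4-cyanophenyl with the lowest number, through 2,4-difluorophenyl, to 2-methoxyphenyl with the highest, and each step between them lies beyond the scatter. Nothing in the available data explains this order.

On these data alone, these three rings differ both in which groups they carry and in where those groups stand, so it remains open whether the nitrile itself or its place on the ring goes with the lowest number. Plain phenyl, 4-fluorophenyl, 2-cyanophenyl or a saturated cyclohexyl group on the same nitrogen could help separate these possibilities.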